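Amino for Hydroxy on the Glycolamide Chain

The source may report more compounds than this note shows. Statements on the series, on what has been measured and on what is new or still open speak of the compounds shown alone.

Compound 1 `COc1ccc(C(=O)c2ccc(OC)c3c2OC(C)(C)C=C3)c(NC(=O)CO)c1` gives 100 nM in a functional assay on HeLa cells (Homo sapiens) for antiproliferative activity, read by MTT assay, with a stated time of 48 h; on this read-out lower numbers stand for stronger inhibition and higher numbers for weaker inhibition. Compound 2 `COc1ccc(C(=O)c2ccc(OC)c3c2OC(C)(C)C=C3)c(NC(=O)CN)c1` carries one change against it, (amino in place of hydroxy on a saturated chain carbon bound to a carbonyl carbon), and gives 410 nM in this assay; the step is a 4.1-fold higher number from compound 1 to compound 2 (0.61 log units; beyond the scatter). Compound 3 `C=C(c1ccc(OC)cc1NC(=O)CO)c1ccc(OC)c2c1C=CC(C)(C)O2` has a different core whose difference from compound 1 is not broken down here, and in this assay compound 3 gives 100 nM, level with compound 1. Compound 4 `C=C(c1ccc(OC)cc1NC(=O)CN)c1ccc(OC)c2c1C=CC(C)(C)O2` carries the same change against compound 3, (amino in place of hydroxy on a saturated chain carbon bound to a carbonyl carbon), the second time this change appears among these compounds. Compound 4 is expected to follow the earlier step, giving an estimated step of a 4.0-fold higher number from compound 3 to compound 4 (0.60 log units; beyond the scatter) because a 4.1-fold higher number from compound 1 to compound 2 (0.61 log units; beyond the scatter) set the size once before on a matching pair. Compound 4 is therefore estimated at 400 nM in this assay, roughly between 200 nM and 800 nM.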

Compound 4, half-maximal inhibitory concentration: 200 nM
Compound 4: the middle estimate sits 2.0-fold (0.30 log units) above what was measured; low and high end bracket the measured number.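

In this assay the change from hydroxy to amino gives a 2.0-fold higher number from compound 3 to compound 4 (0.30 log units; within the scatter) on the second core, a step that alone cannot be told apart from repeat measurement. Set beside the step on the first core, it does not differ in size by more than two such steps can scatter: the same change on two cores in this assay, a 4.1-fold higher number (0.61 log units; beyond the scatter) from compound 1 to compound 2 and a 2.0-fold higher number (0.30 log units; within the scatter) from compound 3 to compound 4, 2.1-fold (0.31 log units) apart, within the scatter of two such steps. The change therefore carries across these two cores without a measurable difference, but with one pair per core this does not show that the size is the same, nor that it would hold on a third core.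

The compounds shown leave open how a dimethylamine or a carboxylic acid would read at this place on the chain. They also leave open what a longer chain would do on either core.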